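Two Aryl Hydrazones Against a Flavin Amine Oxidase

The source may report more compounds than this note shows. Statements on the series, on what has been measured and on what is new or still open speak of the compounds shown alone.

Within the data shown here, compound 1 `Fc1ccc(-c2csc(N/N=C\c3cccnc3)n2)cc1` and compound 2 `Fc1ccc(-c2csc(N/N=C\c3cccs3)n2)c(F)c1` share a core and differ in two places at once, so no single-change step between them can be drawn. In an in vitro assay on BTI-TN-5B1-4 cells for inhibition of Amine oxidase [flavin-containing] A (Homo sapiens), read by Amplex Red, with a stated time of 15 min, tested at 100 uM (on this read-out lower numbers stand for less inhibition and higher numbers for more inhibition at the one concentration tested (going by the name of the read-out)), compound 1 gives 40%, and in this assay compound 2 gives 40%, which stands level with compound 1 at the digits shown, a difference that lies within the usual scatter. Compound 3 `Fc1ccc(-c2csc(N/N=C\c3cccnc3)n2)c(F)c1` has not yet been measured. It differs from compound 2 in one place: pyridin-3-yl in place of thiophen-2-yl on a carbon with a double bond to nitrogen. Since the two measured compounds are indistinguishable despite their two differences, the step from compound 2 to compound 3 in this assay is expected to be small, with no direction beyond the scatter, as no change at the digits printed from compound 2 to compound 3 (within the scatter) expresses. Compound 3 is therefore expected to give about 40% in this assay, in a range from 25% to 55%.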

Compound 3, a percentage reported as inhibition, at one concentration (the size of the read-out at that concentration, not a potency): 40%
Beside the measured number, compound 3's estimate shows no gap at the digits printed; the measured number falls inside the stated range.
By their numbers in this assay, from the lowest: compounds 1, 2 and 3 (each within the scatter of the next).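

Among these compounds, each of the two differences between the earlier compounds can now be read alone: with pyridin-3-yl in place of thiophen-2-yl on a carbon with a double bond to nitrogen, this assay shows no change at the digits printed from compound 2 to compound 3 (within the scatter), and with fluoro in place of hydrogen on an aromatic carbon it shows no change at the digits printed from compound 1 to compound 3 (within the scatter). Neither change alone moves the read-out beyond the usual scatter, so the level values of compound 1 and compound 2 do not conceal two large opposing effects. No measurement here explains why these changes leave the read-out flat.

Still open, from the compounds shown here alone, is whether the fluoro step would hold with thiophen-2-yl in place of pyridin-3-yl. Also open, going by these compounds, is whether a different kind of group on that carbon, such as a carboxylic acid or a longer alkyl chain, would shift the read-out.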